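The compounds below may be only part of what the source reports. "The series", "measured", "known", "first", "only" and "open" are said of these compounds alone.

Measured in an ADME assay on microsomes from liver (Rattus norvegicus) for metabolic stability, read by LC-MS; a lower number here means slower removal, a higher number faster removal of the compound:
Compound 1, `COc1cc(N2CCN(C(=O)CN3CCc4ccccc43)CC2)ccc1-c1cnc(C)o1`: 160 mL.min-1.g-1
Compound 2, `COc1cc(N2CCN(C(=O)N[C@@H](C)c3cccc4ccccc34)CC2)ccc1-n1cc(C)nn1`: 230 mL.min-1.g-1
Compound 3, `COc1cc(N2CCN(C(=O)Cn3cnc4cc(C(F)(F)F)ccc43)C[C@@H]2C)ccc1-c1cnc(C)o1`: 67 mL.min-1.g-1

Compound 2 has the highest of the three numbers in this assay. Against compound 1 its number lies within the scatter, so the two cannot be ordered; against compound 3 the gap is beyond the scatter, compound 3 giving the lower number. For the measured compounds named here, no pair among the measured compounds differs in one place only, so no single step of this kind has been measured.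

Compound 4, `COc1cc(N2CCN(C(=O)N[C@@H](C)c3cccc4ccccc34)CC2)ccc1-c1cnc(C)o1`, is compound 2 with one change: 2-methyl-1,3-oxazol-5-yl in place of 4-methyl-1H-1,2,3-triazol-1-yl on an aromatic carbon. Compound 1 carries the same 2-methyl-1,3-oxazol-5-yl group but a different amide part, so its value does not isolate this change. Going by the values given here, with no measured step for it, the expectation in this assay is a step of no more than the scatter, in either direction. Compound 4 is therefore expected to give 200 mL.min-1.g-1, with a range from 110 mL.min-1.g-1 to 400 mL.min-1.g-1. The expected step that this estimate means is a 1.2-fold lower number from compound 2 to compound 4 (0.06 log units; within the scatter), and it is expected to stay within the scatter.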

Compound 4, intrinsic clearance in microsomes: 130 mL.min-1.g-1
Estimate against measurement, compound 4: 1.5-fold (0.19 log units) above, and the stated range covers the measured number.
By their numbers in this assay, from the lowest: compounds 3, 4, 1 and 2 (each within the scatter of the next, the first and the last beyond it).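

In this assay, 2-methyl-1,3-oxazol-5-yl in place of 4-methyl-1H-1,2,3-triazol-1-yl, on the aromatic carbon ortho to a methoxy group and para to a large group, gives a 1.8-fold lower number from compound 2 to compound 4 (0.25 log units; within the scatter), the only step shown that isolates a single place. Both groups hold 6 heavy atoms and differ in their ring hetero atoms, 3 against 2, and this exchange of one five-membered aromatic ring for another does not separate the two compounds beyond the scatter. No supporting measurement bears on the reason for this step.

As far as these compounds go, whether an amine or a carboxylic acid on this aromatic carbon would give a step beyond the scatter remains open. Also open, from the compounds shown here alone, is whether the same ring exchange gives a step of similar size when the rest of the molecule carries a different amide part.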